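A heteroaryl cap on the sulfonamide of compound 2

The compounds below may be only part of what the source reports. "The series", "measured", "known", "first", "only" and "open" are said of these compounds alone.

Compound 2, `CC(C)(C)c1cc(C(C)(C)C)c2oc(=O)c(/C=N/c3ccc(S(N)(=O)=O)cc3)c(Cl)c2c1`, gives 16 nM in a functional assay on MCF7 cells (Homo sapiens) for cytotoxicity, read by CCK-8 assay, with a stated time of 48 h (a lower number here means a stronger inhibitor, a higher number a weaker inhibitor), the lowest of the two numbers recorded. Compound 1, `O=c1oc2ccccc2c(Cl)c1/C=N/c1ccc(S(=O)(=O)Nc2nccs2)cc1`, gives 160 nM in this assay; it differs from compound 2 in more than one place, so its higher number cannot be tied to any single change. Compound 3, `Cc1cc(NS(=O)(=O)c2ccc(/N=C/c3c(Cl)c4cc(C(C)(C)C)cc(C(C)(C)C)c4oc3=O)cc2)no1`, carries 5-methyl-1,2-oxazol-3-yl in place of hydrogen on a sulfonamide nitrogen. For the measured compounds named here, no measured pair isolates this change, so only a modest step is expected, a 1.9-fold higher number from compound 2 to compound 3 (0.27 log units; within the scatter), not clearly beyond the scatter. Compound 3 is therefore expected to give 30 nM, within a range of 8 nM to 120 nM.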

Compound 3, half-maximal inhibitory concentration: 64 nM
Beside the measured number, compound 3's estimate is 2.1-fold (0.33 log units) below it, and the stated range covers the measured number.
By their numbers in this assay, from the lowest: compound 2; then compound 3; then compound 1.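

In this assay, for the compounds shown here, replacing hydrogen on the sulfonamide nitrogen with 5-methyl-1,2-oxazol-3-yl gives a 4.0-fold higher number from compound 2 to compound 3 (0.60 log units; beyond the scatter), the first reading of a single change at this position. The position therefore responds to this substitution, and the unsubstituted sulfonamide of compound 2 gives the lower number of the pair. Nothing available explains the shift.

The compounds shown leave open whether the rise comes from this particular ring or from losing the hydrogen itself. A plain methyl group or a pyridine ring on that nitrogen would help separate the two.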